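Working notes: anilide series, methoxy to iodo step

A few compounds are considered here, and "the series" means these few. Any claim that something is new, unique, unknown or untested is made for them only; others in the source may bear on it.

Measured so far:
compound 1, `Cn1c(Cc2nn(C)c(=O)c3ccccc23)nnc1SCCCC(=O)Nc1ccc(Cl)cc1Cl`: 9800 nM
compound 2, `Cn1c(Cc2nn(C)c(=O)c3ccccc23)nnc1SCCCCCCCCCCC(=O)Nc1ccc(Cl)cc1Cl`: 3300 nM
compound 3, `COc1ccc(NC(=O)CCCCCCCSc2nnc(Cc3nn(C)c(=O)c4ccccc34)n2C)cc1`: 3900 nM

All three numbers come from an assay on isolated protein (Mus musculus) for inhibition of IL15-IL15 receptor (Homo sapiens), read by resazurin assay, with stated times of 30 min and 2.5 days; a higher number here means a weaker inhibitor, a lower number a stronger inhibitor. Compound 3 carries the second highest of the three numbers. Its nearest neighbour is compound 2, whose number sits within the scatter of that of compound 3, so the two cannot be ordered. Compound 1 is the furthest, with a number that is higher than that of compound 3 by a margin beyond the scatter. Among the compounds with values here, no pair of the measured compounds differs in one place only, so no single structural step has a measured size in this assay.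

Compound 4, `Cn1c(Cc2nn(C)c(=O)c3ccccc23)nnc1SCCCCCCCC(=O)Nc1ccc(I)cc1`, has not been measured. It differs from compound 3 in one place: iodo in place of methoxy on an aromatic carbon. The change sits on an aromatic carbon of a six-membered aromatic ring of carbon only, para to a large group, and the rest of the molecule is unchanged.

With no measured step of this kind in the series, the size of the step from compound 3 to compound 4 is expected to stay within the scatter, with no preferred direction, as a 1.1-fold lower number from compound 3 to compound 4 (0.05 log units; within the scatter). Compound 4 is therefore estimated at 3500 nM, with a range from 1400 nM to 9000 nM.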

Compound 4, half-maximal inhibitory concentration: 1300 nM
Compound 4: the middle estimate sits 2.7-fold (0.43 log units) above what was measured, and the stated range ends above it.
By their numbers in this assay, from the lowest: compound 4; then compounds 2 and 3 (each within the scatter of the next); then compound 1.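

In this assay, within the data shown here, this is the first measured step at this position: a 3.0-fold lower number from compound 3 to compound 4 (0.48 log units; beyond the scatter), with iodo in place of methoxy on an aromatic carbon para to a large group, and the chain and the shared core unchanged. Among these compounds, the earlier compounds included no pair differing in one place, so this pair is the first to show that a change at this position alone can shift the number beyond the scatter, here towards a stronger inhibitor. No measurement shown bears on the cause of this step.

On these data alone, the step rests on one pair, so it remains open whether the lower number is particular to iodo or also extends to other groups on this carbon, such as bromo, chloro, methyl or trifluoromethyl. Among the compounds shown here, it is also open whether a step of this size would hold on a shorter or longer chain than the one shared by compound 3 and compound 4, and how an amine or a carboxylic acid at this position would compare.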